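Swapping a Benzofuran for an Indole: Solubility Outlook

A few compounds are considered here, and "the series" means these few. Any claim that something is new, unique, unknown or untested is made for them only; others in the source may bear on it.

Among the compounds with values here, compound 1 `COc1cccc(CN2C(=O)CN(C(=O)c3cc4cc(OC)ccc4o3)C[C@@H]2CCc2ccccc2)c1` has been measured in a physicochemical assay for solubility, read by spectrophotometry, in phosphate buffer, with a stated time of 2 h, at pH 7.4 (on this read-out higher numbers stand for higher solubility and lower numbers for lower solubility), where compound 1 gives 4900 nM, the only plain number in this set. Compound 2 `COc1ccc2[nH]c(C(=O)N3CC(=O)N(Cc4ccccc4)[C@@H](CN4CCC(OC)CC4)C3)cc2c1` reaches only a limit of this assay, > 25000 nM, so no number is known for it (the limit of > 25000 nM in this assay, at which 1 of the 2 values shown sits). Compound 3 `COc1cccc(CN2C(=O)CN(C(=O)c3cc4cc(OC)ccc4[nH]3)C[C@@H]2CCc2ccccc2)c1` differs from compound 1 in one place: 5-methoxy-1H-indol-2-yl in place of 5-methoxy-1-benzofuran-2-yl on a carbonyl carbon. Within the data shown here, no measured pair shows this change on its own, so its effect is untested. The step from compound 1 to compound 3 is expected to be small, a 1.2-fold higher number from compound 1 to compound 3 (0.09 log units; within the scatter), within the usual scatter. Compound 3 is therefore estimated at 6000 nM, ranging from 2500 nM to 15000 nM.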

Compound 3, solubility: 5100 nM
Compound 3: the middle estimate sits 1.2-fold (0.07 log units) above what was measured, within the range that was stated.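

In this assay, this change on a carbonyl carbon now has a direct reading, which gives a 1.0-fold higher number from compound 1 to compound 3 (0.02 log units; within the scatter) and so leaves the two groups indistinguishable here. On this shared core, 5-methoxy-1H-indol-2-yl can therefore stand in for 5-methoxy-1-benzofuran-2-yl with no measurable difference, even though it brings a hydrogen-bond donor. Nothing shown bears on why the two read alike. Still open, from the compounds shown here alone, is whether a pyridine ring or a group carrying a carboxylic acid at this place would shift the reading beyond the scatter.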